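The source may report more compounds than this note shows. Statements on the series, on what has been measured and on what is new or still open speak of the compounds shown alone.

Measured so far in a functional assay on FaDu cells (Homo sapiens) for cytotoxicity, read by MTT assay, with a stated time of 72 h; a lower number here means that less compound is tolerated, a higher number that more compound is tolerated:
compound 1, `COCCn1cc(C(=O)C(=O)Nc2ccc(OCC(=O)O)nc2)c2ccccc21`, gives > 10000 nM
compound 2, `COC(=O)CCn1cc(C(=O)C(=O)Nc2ccc(OC)nc2)c2ccccc21`, gives 168 nM
compound 3, `COCCn1cc(C(=O)C(=O)Nc2ccc(OC)nc2)c2cc(OC)ccc21`, gives > 10000 nM

Compound 2 is the only one of the three that returns a number in this assay. The value of compound 1 is a limit of the assay, not a number. The value of compound 3 is likewise a limit. Among the compounds with values here, both of these sit at the limit of > 10000 nM in this assay, at which 2 of the 3 values shown sit, so compound 2 stands alone with its number and no step between measured compounds can be drawn from the set. Within the data shown here, each of compound 1 and compound 3 differs from compound 2 in more than one place, and what they show is only that the two limit compounds tolerate more material than compound 2 does.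

Compound 4, `COc1ccc(NC(=O)C(=O)c2cn(CCC(=O)O)c3ccccc23)cn1`, has not been measured. It arises from compound 2 by hydrogen in place of methyl on an oxygen next to a carbonyl group. Nothing among the measured compounds isolates this change, and no cause can be named for any outcome. The expectation for the step from compound 2 to compound 4 in this assay is a rise of moderate size toward a higher tolerated concentration, beyond the usual scatter, written as a 15-fold higher number from compound 2 to compound 4 (1.17 log units; beyond the scatter). Compound 4 is accordingly estimated at 2500 nM, within a range from 400 nM to 10000 nM, with a fair chance that the assay reports only a limit.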

Compound 4, concentration lethal to 50% of the cells: > 10000 nM
Compound 4: a limit, no number; the forecaster's own chance of this, stated with the estimate: 35%; at least 4.0-fold (0.60 log units) between middle value and limit.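

In this assay, hydrogen in place of methyl on an oxygen next to a carbonyl group, which turns methoxycarbonyl into carboxy, gives an at least 59-fold higher number from compound 2 to compound 4 (1.77 log units; beyond the scatter). Compound 4 gives > 10000 nM, a limit of the assay and not a number. This is the first single change that can be read in the series: removing one methyl from the ester separates the only number in the set from a limit, while the true size of the step stays bounded by where the assay stops: the limit of > 10000 nM in this assay, at which 3 of the 4 values shown sit.

The compounds shown leave open whether the number of compound 2 depends on the methyl ester in particular, or would also appear with an ethyl ester, a primary amide or a longer chain carrying the methoxycarbonyl group. Also open, from the compounds shown here alone, are the number compound 4 would have beyond the limit and whether an amine at the end of the chain would return a number in this assay.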